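Trifluoromethyl added to the phenyl of compound 3

The source may hold more compounds than are shown below. What is called first, only, known or untested is meant among the compounds shown, and "the series" means these compounds.

Compound 3 `CCOC(=O)C1=Cc2ccccc2OC1(OCc1cn(-c2ccccc2)nn1)C(F)(F)F` is recorded in a functional assay on A549 cells (Homo sapiens) for inhibition, read by MTT assay, with a stated time of 24 h (a lower number here means a stronger inhibitor, a higher number a weaker inhibitor), only as a limit, > 150000 nM. Compound 1 `CCOC(=O)C1=Cc2ccccc2OC1(OCc1cn(CC(=O)Nc2cccc(F)c2)nn1)C(F)(F)F` likewise gives a limit, > 150000 nM. Compound 2 `CCOC(=O)C1=Cc2ccccc2OC1(OCc1cn(CC(=O)Nc2ccccc2F)nn1)C(F)(F)F` gives 50100 nM; an at least 2.9-fold lower number from compound 1 to compound 2 (0.47 log units; beyond the scatter), an at least 2.9-fold higher number from compound 2 to compound 3 (0.47 log units; beyond the scatter), and a step that the two limits leave unreadable from compound 1 to compound 3. Compound 3 therefore sits at the limit of > 150000 nM in this assay, at which 2 of the 3 values shown sit.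

Compound 4 `CCOC(=O)C1=Cc2ccccc2OC1(OCc1cn(-c2cccc(C(F)(F)F)c2)nn1)C(F)(F)F` differs from compound 3 by trifluoromethyl in place of hydrogen on an aromatic carbon. Among the compounds with values here, no measured step alters a substituent on the phenyl carried by the aromatic nitrogen, so none bears directly on this change; the measured steps show only that the phenyl-bearing compound 3 is at the limit. For compound 4 the value in this assay is expected to stay at or near that limit, with a number no higher from compound 3 to compound 4 (the limit leaves the size open) expected to be no step beyond the scatter. Compound 4 is estimated at 150000 nM, between 50000 nM and 400000 nM.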

Compound 4, half-maximal inhibitory concentration: > 150000 nM
Compound 4 ended at the assay's limit; the forecaster's own chance of this, stated with the estimate: 65%; the middle value sits exactly at the limit.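

In this assay compound 4 gives > 150000 nM as a limit only, so trifluoromethyl on the phenyl of compound 3 brings no readable gain. The steps to compound 4 from compound 3 and from compound 1 cannot be read, since both ends of each are limits. Within the data shown here, the one readable step is an at least 2.9-fold higher number from compound 2 to compound 4 (0.47 log units; beyond the scatter) and it leaves compound 2 as the only compound off the limit: (the limit of > 150000 nM in this assay, at which 3 of the 4 values shown sit).

From the compounds shown here alone, whether any substituent on this phenyl can bring a value off the limit stays open. An amine or a carboxylic acid in place of trifluoromethyl would test this.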